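The source may report more compounds than this note shows. Statements on the series, on what has been measured and on what is new or still open speak of the compounds shown alone.

Of the compounds shown here, three have been measured in a functional assay on DU-145 cells (Homo sapiens) for inhibition, read by trypan blue exclusion, with a stated time of 96 h; a higher number here means a weaker inhibitor of growth, a lower number a stronger inhibitor of growth. Compound 1 `O=C(/C(=C\c1ccc(Cl)cc1)Sc1ccc(Br)cc1)c1ccc(Br)cc1` gives 1000 nM. Compound 2 `O=C(O)c1ccc(C(=O)/C(=C\c2ccc(Cl)c([N+](=O)[O-])c2)SCc2ccc(C(F)(F)F)cc2)cc1` gives 1000 nM, level with compound 1 at the digits shown; together these two sit at the lowest numbers of the three. Compound 3 `CSc1ccc(/C=C(\C(=O)c2ccc(Cl)cc2)S(=O)(=O)Cc2ccc(C)cc2)cc1` gives 10000 nM, a number that lies beyond the scatter from that of compound 2.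

Compound 4 `O=C(O)c1ccc(C(=O)/C(=C\c2ccc(Cl)c([N+](=O)[O-])c2)SCc2ccccc2F)cc1` has not yet been measured in this assay. It differs from compound 2 in one place: 2-fluorophenyl in place of 4-(trifluoromethyl)phenyl on a saturated chain carbon bound to a sulfur. Going by the values given here, no measured pair shows this change, so nothing in the numbers at hand tells how it moves the read-out. The change touches only the group on the saturated chain carbon bound to a sulfur, and the rest of compound 2 is kept as it is. The expected step is no change at the digits printed from compound 2 to compound 4 (within the scatter), a change that is expected to stay within the usual scatter. Compound 4 is therefore estimated at 1000 nM, with a range from 400 nM to 3000 nM.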

Compound 4, concentration for 50% growth inhibition: 1000 nM
The estimate for compound 4 equals the measured number at the digits printed; the measured number falls inside the stated range.
By their numbers in this assay, from the lowest: compounds 1, 2 and 4 (each within the scatter of the next); then compound 3.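

In this assay, going from 4-(trifluoromethyl)benzyl to 2-fluorobenzyl gives no change at the digits printed from compound 2 to compound 4 (within the scatter), the only pair shown that differs in this one place. The number therefore holds when the group goes from 10 heavy atoms to 7 and from 3 fluorines to 1, so at least these two fluorinated benzyl groups are interchangeable in this read-out. Nothing measured here explains why the number holds.

Both groups shown are fluorine-bearing aromatic rings, so it remains open whether a plain benzyl group, a longer alkyl chain or a ring carrying an amine or a carboxylic acid would keep the number at this place. On these data alone, it also remains open whether the same swap would behave alike on a different core.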